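This account rests on a few compounds, and the source may have more. Where it says the series, first, only, none or still open, it means among the compounds named here.

Three compounds built on one shared core were tested in a functional assay on U-87MG ATCC cells (Homo sapiens) for cytotoxicity, read by MTT assay, with a stated time of 48 h; on this read-out higher numbers stand for weaker inhibition and lower numbers for stronger inhibition. Compound 1 `C/C(=N/NC(=S)Nc1ccccc1I)c1ccccn1` gives 6.1 nM, and compound 2 `C/C(=N/NC(=S)Nc1ccc(Cl)cc1)c1ccccn1` gives 1.7 nM. Compound 3 `CC(=NNC(=S)Nc1cccc(I)c1)c1ccccn1` gives 84 nM, the highest number of the three, separated from each of the other two by more than the usual scatter of such measurements. Compound 4 `C/C(=N\NC(=S)Nc1cccc(I)c1)c1ccccn1` differs from compound 3 in a single respect: the two compounds have the same atoms and bonds; at least one stereo element is drawn with a configuration in one of them and without one in the other: 1 of 1 stereo elements differ; a double bond is drawn without a configuration in compound 3 and E in compound 4. Since the atoms and bonds are identical, and only the drawing of the double bond configuration has been made explicit, no change beyond the scatter is expected; the expected step is no change at the digits printed from compound 3 to compound 4 (within the scatter), essentially none. In this assay compound 4 is therefore expected to give about 84 nM, with a likely range from 30 nM to 240 nM.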

Compound 4, half-maximal inhibitory concentration: 84 nM
Estimate against measurement, compound 4: no gap at the digits printed; low and high end bracket the measured number.
By their numbers in this assay, from the lowest: compound 2; then compound 1; then compounds 3 and 4 (each within the scatter of the next).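

In this assay the result is no change at the digits printed from compound 3 to compound 4 (within the scatter), so drawing the double bond as E leaves the number where it stood. Among the compounds shown here, this is the first pair here that differs in one place, and that difference lies only in how the structures are drawn: the fact that one of compounds 3 and 4 is drawn with a defined configuration and the other without, at the place where they differ. The pair therefore gives no measure of what a real change in structure does in this series.

The compounds shown leave open how the opposite configuration at this double bond would read, and whether a methoxy group in place of the iodine of compound 4 would shift the number.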